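Working notes: from compound 3 to compound 4

The source may report more compounds than this note shows. Statements on the series, on what has been measured and on what is new or still open speak of the compounds shown alone.

For the measured compounds named here, in an ADME assay on HEL cells (Homo sapiens) for cytotoxicity (on this read-out higher numbers stand for lower toxicity in this test and lower numbers for higher toxicity in this test), compound 3 `O=C(COc1cccc2ccccc12)N/N=C/c1ccc([N+](=O)[O-])cc1` gives 14.2 ug/mL and holds the lowest number of the three compounds measured so far. Compound 1 `O=C(COc1cccc2ccccc12)N/N=C/c1ccc(O)cc1` stands at 60.6 ug/mL on the same read-out, and compound 2 `O=C(COc1cccc2ccccc12)N/N=C/c1ccccc1Br` gives 100 ug/mL there. Both lie beyond the scatter from compound 3.

Compound 4 `CSc1ccc(/C=N/NC(=O)COc2cccc3ccccc23)cc1` keeps the shared core and differs from compound 3 in one place. The change is methylsulfanyl in place of nitro on an aromatic carbon with methylsulfanyl in place of nitro on an aromatic carbon, para to a large group.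

Going by the values given here, two measured steps bear on this. The step that introduces nitro is a 4.3-fold lower number from compound 1 to compound 3 (0.63 log units; beyond the scatter) with nitro in place of hydroxy on an aromatic carbon, modest in size but beyond the scatter. The other is a 1.7-fold higher number from compound 1 to compound 2 (0.22 log units; within the scatter) and gives no separation between the two compounds without nitro. Among the compounds with values here, no compound with methylsulfanyl has been measured, so the size of the step rests on these comparisons alone.

With nitro gone, a modest rise is expected, estimated as a 2.8-fold higher number from compound 3 to compound 4 (0.45 log units; beyond the scatter) toward the numbers of the compounds without nitro. For compound 4 the estimate is 40 ug/mL with an expected range of 15 ug/mL to 100 ug/mL in this assay once measured.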

Compound 4, half-maximal cytotoxic concentration: > 100 ug/mL
Compound 4: no number, only a limit (the forecaster's own chance of this, stated with the estimate: 15%); middle value at least 2.5-fold (0.39 log units) away from the limit.
By their numbers in this assay, from the lowest: compound 3; then compounds 1 and 2 (each within the scatter of the next).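

In this assay, the result for compound 4 is a limit of the assay and not a number: the limit of > 100 ug/mL in this assay, at which 1 of the 4 values shown sits. At this position, on an aromatic carbon para to a large group, methylsulfanyl in place of nitro gives an at least 7.0-fold higher number from compound 3 to compound 4 (0.84 log units; beyond the scatter), so the step away from nitro is now measured with a second group and not only with hydroxy, and it points the same way, toward lower toxicity in this test. Against hydroxy at the same position the step is an at least 1.6-fold higher number from compound 1 to compound 4 (0.21 log units; that floor lies within the scatter), and with that floor inside the scatter, methylsulfanyl and hydroxy are not separated by these data, although the true gap may be wider.

Against 2-bromophenyl the result is a number no lower from compound 2 to compound 4 (the limit leaves the size open) and cannot be read, so the ranking of methylsulfanyl against 2-bromophenyl stays undecided. Whether the low number of compound 3 belongs to nitro alone also stays open: the compounds shown carry no amine, carboxylic acid or longer alkyl chain on sulfur at this position, and a nitrile there would test the same question.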